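Replacing the thiadiazole chain end with a carboxy group

The source may report more compounds than this note shows. Statements on the series, on what has been measured and on what is new or still open speak of the compounds shown alone.

Measured so far:
compound 1 `C/C(=N\OCCF)c1ccc(Sc2cc(F)cc(C3CCOCC3)c2)cc1` gives 40 nM in a functional assay (blood) for inhibition, with Homo sapiens as the target; a higher number here means a weaker inhibitor, a lower number a stronger inhibitor;
compound 2 `C/C(=N\OCCSc1nnc(C)s1)c1ccc(Sc2cc(F)cc(C3CCOCC3)c2)cc1` gives 230 nM in this assay.

Among these two numbers compound 2 stands highest, separated from compound 1 by a 5.8-fold higher number from compound 1 to compound 2 (0.76 log units; beyond the scatter). Compound 3 `C/C(=N\OCC(=O)O)c1ccc(Sc2cc(F)cc(C3CCOCC3)c2)cc1` is the next step from compound 2: carboxy in place of ((5-methyl-1,3,4-thiadiazol-2-yl)sulfanyl)methyl on a saturated chain carbon bound to an oxygen. Among the measured compounds shown here, the one measured step that bears on this is the one from compound 1 to compound 2, where the fluoro was exchanged for the (5-methyl-1,3,4-thiadiazol-2-yl)sulfanyl group and the number rose modestly but beyond the scatter. Compound 3 removes that group again, yet the carboxy that enters is unlike the fluoro of compound 1, so the return is uncertain. A modest move towards a lower number is expected for compound 3, about a 2.9-fold lower number from compound 2 to compound 3 (0.46 log units; beyond the scatter). Compound 3 is therefore estimated at 80 nM, within a range from 25 nM to 300 nM.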

Compound 3, half-maximal inhibitory concentration: 740 nM
For compound 3 the middle estimate is 9.3-fold (0.97 log units) below the measured one, outside the stated range (above it).
By their numbers in this assay, from the lowest: compound 1; then compound 2; then compound 3.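

In this assay the loss of the ((5-methyl-1,3,4-thiadiazol-2-yl)sulfanyl)methyl group does not bring the number back towards that of the fluoro compound. With the carboxy group in its place, the number rises further (a 3.2-fold higher number from compound 2 to compound 3 (0.51 log units; beyond the scatter)). Against the fluoromethyl end, the same carboxy group gives the largest step seen at this place on the chain (a 19-fold higher number from compound 1 to compound 3 (1.27 log units; beyond the scatter)), so a larger group at the chain end is not what gives the highest number here, and compound 3, with the smallest of the three groups by heavy atoms among those leaving and entering, is the weakest of the three. Nothing available here explains this order.

Open, going by these compounds, is whether a methyl ester or a primary amide in place of the carboxy group would give a number nearer that of compound 1. Also open, on these data alone, is how an amine at the chain end, or a longer chain carrying the carboxy group, would compare.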